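Amine side chain: from compound 3 to compound 4

This account rests on a few compounds, and the source may have more. Where it says the series, first, only, none or still open, it means among the compounds named here.

Values in a functional assay on SK-BR-3 cells (Homo sapiens) for antiproliferative activity; a lower number here means a stronger inhibitor, a higher number a weaker inhibitor:
- compound 1 `CC(C)=CCc1cc(C(=O)Nc2cc3ccc(OCC4CCCN(C)C4)c(C)c3oc2=O)ccc1O` gives 1300 nM
- compound 2 `CCNCCCOc1ccc2cc(NC(=O)c3ccc(O)c(CC=C(C)C)c3)c(=O)oc2c1C` gives 720 nM
- compound 3 `CCN(CC)CCCOc1ccc2cc(NC(=O)c3ccc(O)c(CC=C(C)C)c3)c(=O)oc2c1C` gives 4900 nM

Compound 3 stands highest of the three at 4900 nM and is the weakest so far. Compound 4 `CC(C)=CCc1cc(C(=O)Nc2cc3ccc(OCCCNC(C)C)c(C)c3oc2=O)ccc1O` differs from it by isopropylamino in place of diethylamino on a saturated chain carbon, three bonds along the chain from an oxygen on an aromatic ring and so keeps a hydrogen on the amine nitrogen, as compound 2 does. The nearest measured change, ethyl in place of hydrogen on an amine nitrogen, gave a 6.8-fold higher number from compound 2 to compound 3 (0.83 log units; beyond the scatter) and compound 4 runs the opposite way. The steps of a 3.8-fold higher number from compound 1 to compound 3 (0.58 log units; beyond the scatter) and a 1.8-fold lower number from compound 1 to compound 2 (0.26 log units; within the scatter) also leave compound 3 apart. A lower number is therefore expected, with a 4.9-fold lower number from compound 3 to compound 4 (0.69 log units; beyond the scatter) as the estimated step, resting on this single pair. The expected value for compound 4 is 1000 nM within a range from 400 nM to 2800 nM as estimated.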

Compound 4, half-maximal inhibitory concentration: 750 nM
Beside the measured number, compound 4's estimate is 1.3-fold (0.12 log units) above it; the range from low to high includes it.
By their numbers in this assay, from the lowest: compounds 2, 4 and 1 (each within the scatter of the next); then compound 3.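

In this assay, diethylamino is not the only amine on this chain to separate from the others: the isopropylamino change gives a step beyond the scatter (a 6.5-fold lower number from compound 3 to compound 4 (0.82 log units; beyond the scatter)), and this amine nitrogen keeps its hydrogen. The added methyl on the chain carbon bound to the amine nitrogen leaves no readable change (a 1.0-fold higher number from compound 2 to compound 4 (0.02 log units; within the scatter)), and the step from the 1-methylpiperidin-3-yl side chain is also within the scatter (a 1.7-fold lower number from compound 1 to compound 4 (0.24 log units; within the scatter)). Nothing available explains these differences.

Still open, going by these compounds, is whether a tert-butylamino or cyclopropylamino group on the same chain, or a longer chain carrying isopropylamino, would stay level with compound 4.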